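Removing a methyl from the carbamate ring substituent

The compounds below may be only part of what the source reports. "The series", "measured", "known", "first", "only" and "open" are said of these compounds alone.

The two measured compounds share a core and differ only in the group on an oxygen next to a carbonyl group. Compound 1 `CC1(COC(=O)N2CC3COCC(C2)C3Oc2ncnc(Nc3ccc(C#N)cc3Cl)c2F)COC1` gives, in a functional assay for agonist activity at Glucose-dependent insulinotropic receptor (Mus musculus), read by cAMP accumulation (a lower number here means a smaller maximal response, a higher number a larger maximal response), 46%. Compound 2 `CC1(OC(=O)N2CC3COCC(C2)C3Oc2ncnc(Nc3ccc(C#N)cc3Cl)c2F)CCC1` gives, in this assay, 88%, which is the higher of the two numbers shown; the step of a number 42 percentage points higher from compound 1 to compound 2 (beyond the scatter) came with 1-methylcyclobutyl in place of (3-methyloxetan-3-yl)methyl. Compound 3 `N#Cc1ccc(Nc2ncnc(OC3C4COCC3CN(C(=O)OC3CCC3)C4)c2F)c(Cl)c1` has not yet been measured in this assay. It differs from compound 2 by hydrogen in place of methyl on a saturated ring carbon, which is 1-methylcyclobutyl to cyclobutyl. Within the data shown here, the only measured step bearing on this is the one from compound 1 to compound 2, which altered the same group and was large; the present change is smaller, a single carbon removed from a four-membered ring. A step from compound 2 to compound 3 of a number 10 percentage points lower from compound 2 to compound 3 (within the scatter) is therefore expected, with a possible modest decrease. Compound 3 is estimated to give 78% in this assay, with a range from 55% to 95%.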

Compound 3, largest response reached (reported as percent of maximum), in percent of the reference or control that the assay uses: 60%
Compound 3: the middle estimate sits 18 percentage points above what was measured, within the range that was stated.
By their numbers in this assay, from the lowest: compound 1; then compound 3; then compound 2.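

In this assay, the methyl on a saturated ring carbon of the four-membered ring proves to matter on its own: going from 1-methylcyclobutyl to cyclobutyl gave a number 28 percentage points lower from compound 2 to compound 3 (beyond the scatter), a change of one carbon that lies beyond the usual scatter. The earlier pair changed the whole group on the oxygen next to a carbonyl group, so it could not separate the methyl from the rest of that group; the cyclobutyl compound now does part of that work, with a number 14 percentage points higher from compound 1 to compound 3 (beyond the scatter). Among these three compounds, the response therefore rises from (3-methyloxetan-3-yl)methyl to cyclobutyl and again to 1-methylcyclobutyl, though no information here accounts for either rise.

The compounds shown leave open whether an ethyl on the same ring carbon would raise the response beyond that of compound 2 or lower it. They also leave open whether the methyl would count for as much on a cyclopentyl ring, or whether an open-chain tert-butyl group would match the 1-methylcyclobutyl group.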